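A few compounds are considered here, and "the series" means these few. Any claim that something is new, unique, unknown or untested is made for them only; others in the source may bear on it.

Measured so far:
- compound 1, `CN(C[C@H]1COC(N)=N1)c1cccc(Cl)c1`: 27 nM
- compound 2, `C[C@]1(CCc2cccc(Cl)c2)COC(N)=N1`: 330 nM

In a functional assay on HEK293 cells for agonist activity at trace amine-associated receptor 1 (Homo sapiens), read by cAMP accumulation, with a stated time of 30 min (a lower number here means that less compound is needed, a higher number that more compound is needed for the effect), compound 1 gives 27 nM, the lowest number of the two measured. Compound 2, which carries its aryl group on a carbon chain rather than on a nitrogen, gives 330 nM in this assay, a clearly higher number, and the gap between compound 1 and compound 2 lies beyond the usual scatter. The two structures differ in more than one place, so nothing is taken from the pair beyond what the two values show.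

Compound 3, `NC1=N[C@@H](CNc2cccc(Cl)c2)CO1`, follows from compound 1 by a single change: hydrogen in place of methyl on a nitrogen on an aromatic ring. The ring, the chloro substituent and the shared core are untouched. Going by the values given here, no step between measured compounds matches this change, so the expectation rests on the value of compound 1 alone. A small shift toward a higher number is expected, close to the edge of the scatter, with the step of a 2.0-fold higher number from compound 1 to compound 3 (0.31 log units; beyond the scatter) in this assay. For compound 3 the estimate in this assay is 55 nM, with a range from 12 nM to 250 nM.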

Compound 3, half-maximal effective concentration: 580 nM
The estimate for compound 3 lay 11-fold (1.02 log units) below the measured number; measured number above the stated range.
By their numbers in this assay, from the lowest: compound 1; then compounds 2 and 3 (each within the scatter of the next).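

In this assay, the nitrogen on an aromatic ring turns out to be a sensitive place in this series, with hydrogen in place of methyl giving a 21-fold higher number from compound 1 to compound 3 (1.33 log units; beyond the scatter), a large step. The change removes one heavy atom, a single carbon, and involves no ring, no hydrogen-bond donor or acceptor count and no net charge, while the ring, the chloro substituent and the shared core stay the same, so the earlier pair of compounds, which differ in more than one place, could not have shown how much rests on this methyl alone. Nothing measured here gives a reason for the size of this step.

Still open, going by these compounds, is whether an ethyl group, a longer chain or a cyclopropyl group on this nitrogen keeps the number near that of compound 1 at 27 nM or moves it away, as only methyl and hydrogen are compared at this place. Also open, on these data alone, is whether the same change gives a step of similar size when a fluoro or methoxy group stands in place of the chloro substituent.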